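A few compounds are considered here, and "the series" means these few. Any claim that something is new, unique, unknown or untested is made for them only; others in the source may bear on it.

Compound 1, with the structure `O=C(NCc1ccc(F)cc1)c1nc(Br)c2cccnc2c1NCc1ccccc1`, is one of three compounds of a shared core tested in a functional assay on HCT-116 cells (Homo sapiens) for cytotoxicity, read by MTT assay, with a stated time of 72 h; on this read-out lower numbers stand for stronger inhibition and higher numbers for weaker inhibition. In this assay compound 1 gives > 20000 nM, which is a limit of the assay rather than a number, the limit recorded as the limit of > 20000 nM in this assay, at which 1 of the 3 values shown sits. Compound 2, with the structure `N[C@H]1CC[C@H](Nc2c(C(=O)NCc3ccco3)nc(Br)c3cccnc23)CC1`, gives > 10000 nM in this assay, again a limit. Compound 3, with the structure `O=C(NCCCNc1c(C(=O)NCc2ccc(F)cc2)nc(Br)c2cccnc12)c1ccccc1`, gives > 10000 nM in this assay, also a limit; two of the three values sit at the limit of > 10000 nM in this assay, at which 2 of the 3 values shown sit. Going by the values given here, the only single-point change among the measured compounds, a step that the two limits leave unreadable from compound 1 to compound 3, therefore cannot be read in size, and no measured value of compound 1 stands as a number to compare with.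

Compound 4, with the structure `O=C(NCc1ccc(F)cc1)c1nc(Br)c2cccnc2c1N1CCNCC1`, differs from compound 1 by piperazin-1-yl in place of benzylamino on an aromatic carbon. Among the compounds with values here, no measured step bears on this change: the one step recorded, from compound 1 to compound 3, is unreadable, and every value shown is a limit. The expectation for this assay is accordingly no readable step beyond the scatter, with compound 4 estimated at 15000 nM in this assay, in the range 3000 nM to 60000 nM, the estimated step from compound 1 being an at least 1.3-fold lower number from compound 1 to compound 4 (0.12 log units; that floor lies within the scatter).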

Compound 4, half-maximal inhibitory concentration: > 10000 nM
Compound 4: only a limit was reported (the forecaster's own chance of this, stated with the estimate: 70%); the middle value is on the limit's open side.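

In this assay compound 4 gives > 10000 nM, which is a limit and not a number. Compound 1 also stands at a limit, so the step between compound 1 and compound 4 cannot be read. The compounds shown leave open whether any group on the shared core gives a measurable value in this assay.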